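The source may hold more compounds than are shown below. What is called first, only, known or untested is meant among the compounds shown, and "the series" means these compounds.

Working notes on the series. Compound 2 `COc1ccc(/C(C)=N/Nc2ncc(Cl)c(Nc3cccc(NC(=O)/C=C/CN(C)C)c3)n2)cc1` and compound 1 `CN(C)C/C=C/C(=O)Nc1cccc(Nc2nc(N/N=C/c3c[nH]c4ccccc34)ncc2Cl)c1` share one core and differ only in the aryl group on the hydrazone nitrogen. In an ADME assay on HT-29 cells (Homo sapiens) for inhibition, read by MTT assay, with a stated time of 72 h (on this read-out lower numbers stand for stronger inhibition and higher numbers for weaker inhibition), compound 1 gives 9680 nM; in the same assay compound 2 gives 6830 nM. The two numbers stand within the scatter of each other, as the step of a 1.4-fold lower number from compound 1 to compound 2 (0.15 log units; within the scatter) shows, so neither compound can be set apart from the other on these data.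

Compound 3 `C/C(=N\Nc1ncc(Cl)c(Nc2cccc(NC(=O)/C=C/CN(C)C)c2)n1)c1ccncc1` keeps the whole of compound 2 except for one change: pyridin-4-yl in place of 4-methoxyphenyl on a carbon with a double bond to nitrogen. Within the data shown here, the only measured step that touches this position is the one from compound 1 to compound 2, which exchanged the whole aryl hydrazone group and moved the number by less than the scatter. A smaller exchange of one six-membered aromatic ring for another at the same place is therefore expected to give no step beyond the scatter in this assay, in either direction, which is what the expected step of a 1.0-fold higher number from compound 2 to compound 3 (0.01 log units; within the scatter) reflects. On that basis compound 3 is estimated to give 7000 nM in this assay, with an expected range from 2500 nM to 20000 nM.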

Compound 3, half-maximal inhibitory concentration: 10900 nM
Estimate against measurement, compound 3: 1.6-fold (0.19 log units) below, and the stated range covers the measured number.
By their numbers in this assay, from the lowest: compounds 2, 1 and 3 (each within the scatter of the next).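

In this assay, among these compounds, pyridin-4-yl in place of 4-methoxyphenyl on a carbon with a double bond to nitrogen gives a 1.6-fold higher number from compound 2 to compound 3 (0.20 log units; within the scatter), the first reading of an exchange of this ring alone, with the rest of the molecule held fixed. The larger exchange of the whole group on the nitrogen gives a 1.1-fold higher number from compound 1 to compound 3 (0.05 log units; within the scatter), so the three compounds cannot be told apart here, and swapping a carbon-only ring for one with a ring nitrogen leaves no readable mark on the number. Nothing on hand accounts for this flat reading.

Open, from the compounds shown here alone, is whether any group at this place can move the number beyond the scatter, since the three seen so far all carry aromatic rings: a carboxylic acid or a primary amine on the ring, or a saturated ring such as morpholine in place of pyridin-4-yl, would test that. Also open is whether the shared core sets these numbers, which the compounds shown cannot address, as all three keep the same dimethylamino chain and the same chlorine.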